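The source may report more compounds than this note shows. Statements on the series, on what has been measured and on what is new or still open speak of the compounds shown alone.

Among the measured compounds shown here, in an assay for inhibition of leukotriene A-4 hydrolase (Homo sapiens), read by spectrophotometry (on this read-out higher numbers stand for weaker inhibition and lower numbers for stronger inhibition), compound 2 `CCCCCOc1ccc(Oc2ccccc2)cc1` gives 4130 nM, the higher of the two numbers measured so far. For the measured compounds named here, compound 1 `NCCOc1ccc(Oc2ccccc2)cc1` gives 228 nM, and the single measured step, an 18-fold higher number from compound 1 to compound 2 (1.26 log units; beyond the scatter), concerns a change on the saturated chain. Compound 3 `CCCCCOc1ccc(Oc2ccc(O)cc2)cc1` differs from compound 2 in another place: hydroxy in place of hydrogen on an aromatic carbon. Going by the values given here, no measured step touches a hydroxy on an aromatic ring, so nothing here supports a shift beyond the usual scatter in either direction. Compound 3 is therefore estimated at 3500 nM, within a range from 1000 nM to 12000 nM. That estimate means a step of a 1.2-fold lower number from compound 2 to compound 3 (0.07 log units; within the scatter), expected to stay within the scatter.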

Compound 3, half-maximal inhibitory concentration: 2480 nM
Compound 3: the middle estimate sits 1.4-fold (0.15 log units) above what was measured; the range from low to high includes it.
By their numbers in this assay, from the lowest: compound 1; then compounds 3 and 2 (each within the scatter of the next).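

In this assay, hydroxy in place of hydrogen on an aromatic carbon, para to a large group, gives a 1.7-fold lower number from compound 2 to compound 3 (0.22 log units; within the scatter). Among the compounds shown here, this is the first view of this ring position, and this single change leaves the read-out within the usual scatter, unlike the change on the saturated chain. No outside evidence bears on this result.

A carboxylic acid or a methoxy on the same aromatic carbon could behave differently. On these data alone, it also remains open whether hydroxy here would give a similar result alongside the amino chain of compound 1.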